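Cyclohexyl ester in place of thioester on the shared core

The source may report more compounds than this note shows. Statements on the series, on what has been measured and on what is new or still open speak of the compounds shown alone.

Of the compounds shown here, two on the shared core have been measured so far. Compound 1 `CCN(CC)C(=O)C1=C(C)NC(=O)NC1c1ccco1` carries a diethylamino group on the carbonyl carbon, and in an assay on membranes from CHO cells for displacement of a labelled ligand from adenosine receptor A1 (Homo sapiens), read by scintillation counting, with a stated time of 60 min, tested at 1 uM (a higher number here means more inhibition at the concentration tested (going by the name of the read-out), a lower number less inhibition), compound 1 gives 11%. Compound 2 `CCSC(=O)C1=C(C)NC(=O)NC1c1ccco1` carries an ethylsulfanyl group on that carbonyl carbon instead, and in this assay compound 2 gives 6%. For the measured compounds named here, the only measured step, a number 5 percentage points lower from compound 1 to compound 2 (within the scatter), is within the scatter, so these two numbers cannot be ordered; both simply show little inhibition at the concentration tested. Compound 2 has the lowest of the two numbers, with compound 1 the nearest.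

Compound 3 `CC1=C(C(=O)OC2CCCCC2)C(c2ccco2)NC(=O)N1` has not been measured. It differs from compound 2 in one place: cyclohexyloxy in place of ethylsulfanyl on a carbonyl carbon. The step from compound 1 to compound 2 is the only one that bears on this change, and it altered the group on the same carbonyl carbon without moving the number beyond the scatter. On that slim basis no step beyond the scatter is expected in this assay for compound 3; the step of a number 4 percentage points higher from compound 2 to compound 3 (within the scatter) is expected to stay small. Compound 3 is therefore estimated at 10%, within a range from 0% to 25%.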

Compound 3, a percentage reported as inhibition, at one concentration (the size of the read-out at that concentration, not a potency): 1%
Compound 3: the middle estimate sits 9 percentage points above what was measured; measured number inside the range.
By their numbers in this assay, from the lowest: compounds 3, 2 and 1 (each within the scatter of the next).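

Putting cyclohexyloxy on the carbonyl carbon in place of ethylsulfanyl adds a six-membered non-aromatic ring of carbon only, a much larger group than the one it replaces, and yet this assay gives a number 5 percentage points lower from compound 2 to compound 3 (within the scatter) as the result. The comparison with the amide gives a number 10 percentage points lower from compound 1 to compound 3 (within the scatter) as its result, so diethylamino, ethylsulfanyl and cyclohexyloxy on this carbonyl carbon cannot be told apart here, and all three compounds show little inhibition at the concentration tested. Nothing available explains why these numbers stay so close together.

Going by these compounds, whether any group on this carbonyl carbon can lift the number clearly above this low level stays open: a benzyloxy group, a longer chain, a free carboxylic acid or an amine-bearing side chain could each answer that. Because each compound was read at a single concentration, these numbers also leave open how the three compounds would compare at higher concentrations, where a real difference might become visible.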